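Swapping the halogen on the benzyl arm

The compounds below may be only part of what the source reports. "The series", "measured", "known", "first", "only" and "open" are said of these compounds alone.

Compound 1, `Cc1[nH]n(-c2nc3ccccc3[nH]2)c(=O)c1Cc1cccc(Cl)c1`, carries a 3-chlorobenzyl group on a shared core. In an assay on isolated protein for inhibition of alpha-ketoglutarate-dependent dioxygenase alkB homolog 3 (Homo sapiens), read by polymerase chain reaction, with a stated time of 1 h (on this read-out lower numbers stand for stronger inhibition and higher numbers for weaker inhibition), compound 1 gives 540 nM, the higher of the two plain numbers obtained so far. Compound 3, `Cc1[nH]n(-c2nc3cc(Br)ccc3[nH]2)c(=O)c1Cc1ccccc1`, with an unsubstituted benzyl group and a bromine on its core, gives 490 nM in this assay, a gap from compound 1 that lies within the usual scatter. Compound 2, `Cc1[nH]n(-c2nc3ccccc3s2)c(=O)c1C`, has a methyl in place of the benzyl arm and a different core. In this assay compound 2 reaches only the limit of > 10000 nM, a boundary of the measurement rather than a number (the limit of > 10000 nM in this assay, at which 1 of the 3 values shown sits).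

Compound 4, `Cc1[nH]n(-c2nc3ccccc3[nH]2)c(=O)c1Cc1ccc(F)cc1`, differs from compound 1 in one place: 4-fluorophenyl in place of 3-chlorophenyl on a saturated chain carbon bound to an aromatic carbon. Among the compounds with values here, no measured pair isolates such a change, so the expectation rests on compound 1 and compound 3 alone, whose benzyl groups differ yet give numbers within the scatter. The step of a 1.5-fold higher number from compound 1 to compound 4 (0.17 log units; within the scatter) is therefore expected to be small, at most a slight weakening near the scatter. Compound 4 is estimated at 800 nM, within a range from 300 nM to 3000 nM.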

Compound 4, half-maximal inhibitory concentration: 600 nM
For compound 4 the middle estimate is 1.3-fold (0.12 log units) above the measured one; the range from low to high includes it.
By their numbers in this assay, from the lowest: compounds 3, 1 and 4 (each within the scatter of the next). At a limit, above all of these: compound 2.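

Within the data shown here, this is the first pair that differs in only one place, so the benzyl arm can now be judged on its own, with the core held constant. In this assay, the swap of 3-chlorophenyl for 4-fluorophenyl on a saturated chain carbon bound to an aromatic carbon gives a 1.1-fold higher number from compound 1 to compound 4 (0.05 log units; within the scatter), so this position accepts both halogen-bearing rings without a change that can be told from the scatter. The swap alters the halogen and its place on the ring together, and nothing shown accounts for the lack of a clear difference.

From the compounds shown here alone, whether the two halogens would behave alike at the same ring position remains open. So does the effect of an amine or a carboxylic acid on this ring, or of a longer chain in place of the single chain carbon.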